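Benzoyl on the amino nitrogen of compound 2

A few compounds are considered here, and "the series" means these few. Any claim that something is new, unique, unknown or untested is made for them only; others in the source may bear on it.

Three compounds of the series have numbers in an assay on CHO cells for displacement of a labelled ligand from adenosine receptor A3 (Homo sapiens), read by scintillation counting, with a stated time of 60 min; a higher number here means a weaker inhibitor, a lower number a stronger inhibitor. Compound 1 `Nc1nc(-c2cccs2)nc2cn(-c3ccccc3)nc12` gives 9.7 nM. Compound 2 `COc1ccc(-c2nc(N)c3nn(-c4ccccc4)cc3n2)cc1` gives 33 nM. Compound 3 `COc1ccc(-c2nc(N)c3nn(-c4ccc(OC)cc4)cc3n2)cc1` gives 17 nM. Compound 2 thus shows the highest of the three numbers; the nearest is compound 3, with a gap within the scatter, and the furthest is compound 1, with a gap beyond it. The two measured steps are a 3.4-fold higher number from compound 1 to compound 2 (0.53 log units; beyond the scatter) and a 1.9-fold lower number from compound 2 to compound 3 (0.29 log units; within the scatter).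

Compound 4 `COc1ccc(-c2nc(NC(=O)c3ccccc3)c3nn(-c4ccccc4)cc3n2)cc1` differs from compound 2 by benzoyl in place of hydrogen on a nitrogen on an aromatic ring. Among the compounds with values here, both measured steps concern the aromatic substituents on carbon, not the exocyclic nitrogen, so no step bears directly on this change; they only show that the series tolerates such variation with modest movement in this assay. Within the data shown here, the step to compound 4 has no precedent here, and its direction is uncertain. The expectation is that compound 4 gives a number near that of compound 2, with a wide range, estimated at 20 nM (between 4 nM and 100 nM), which corresponds to an expected step of a 1.7-fold lower number from compound 2 to compound 4 (0.22 log units; within the scatter).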

Compound 4, inhibition constant: 6.42 nM
For compound 4 the middle estimate is 3.1-fold (0.49 log units) above the measured one; the measured number falls inside the stated range.
By their numbers in this assay, from the lowest: compounds 4, 1, 3 and 2 (each within the scatter of the next, the first and the last beyond it).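

In this assay, within the data shown here, the amino to benzamido change gives a 5.1-fold lower number from compound 2 to compound 4 (0.71 log units; beyond the scatter), the first step at the nitrogen rather than on an aromatic carbon. For this pair, a free amino group is not needed for a low number: benzoyl, with its 8 heavy atoms and six-membered aromatic ring, is accepted on this nitrogen, and the number falls rather than rises. Nothing available accounts for the size or direction of this step.

The compounds shown leave open whether the benzoyl step carries over to the thiophen-2-yl compound 1 or the dimethoxy compound 3, since this single pair rests on the 4-methoxyphenyl and unsubstituted phenyl groups of compound 2. They also leave open which part of the benzoyl group goes with the lower number, a question that acetyl, benzyl or phenylacetyl on the same nitrogen would address, and whether a methoxybenzoyl or pyridine-3-carbonyl group would shift the number further.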